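This account rests on a few compounds, and the source may have more. Where it says the series, first, only, none or still open, it means among the compounds named here.

In a functional assay on V79 cells (Cricetulus griseus) for cytotoxicity, read by colony formation (a lower number here means a stronger inhibitor, a higher number a weaker inhibitor), compound 1 `CC1(CN)CCN(c2cc3c(cc2F)c(=O)c(C(=O)O)cn3C2CC2)C1` gives 23 ug/mL, and compound 2 `CC1(CN)CCN(c2c(F)cc3c(=O)c(C(=O)O)cn(C4CC4)c3c2C(F)(F)F)C1` gives 110 ug/mL, the higher of the two numbers, so compound 2 is the weaker inhibitor of the pair. Among the measured compounds shown here, the only measured step is a 4.8-fold higher number from compound 1 to compound 2 (0.68 log units; beyond the scatter), a modest change that lies beyond the scatter. It comes with trifluoromethyl in place of hydrogen on an aromatic carbon. Compound 3 `NC1CCN(c2c(F)cc3c(=O)c(C(=O)O)cn(C4CC4)c3c2C(F)(F)F)CC1` keeps that trifluoromethyl group and differs from compound 2 in its amine: 4-aminopiperidin-1-yl in place of 3-(aminomethyl)-3-methylpyrrolidin-1-yl on an aromatic carbon. Here 4-aminopiperidin-1-yl stands in place of 3-(aminomethyl)-3-methylpyrrolidin-1-yl on an aromatic carbon, ortho to a fluoro group and ortho to a trifluoromethyl group. For the measured compounds named here, no measured step covers this exchange, and the one available concerns a group that stays put, so it gives neither a size nor a direction. In this assay, therefore, no step beyond the scatter is expected, though the uncertainty is wide. The expected change is a 1.1-fold lower number from compound 2 to compound 3 (0.04 log units; within the scatter). For compound 3 the estimate is 100 ug/mL, with an expected range from 35 ug/mL to 280 ug/mL.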

Compound 3, half-maximal inhibitory concentration: 20 ug/mL
Compound 3: the middle estimate sits 5.0-fold (0.70 log units) above what was measured, outside the stated range (below it).
By their numbers in this assay, from the lowest: compounds 3 and 1 (each within the scatter of the next); then compound 2.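

In this assay, the group on the aromatic carbon ortho to a fluoro group and ortho to a trifluoromethyl group proves to matter: 4-aminopiperidin-1-yl in place of 3-(aminomethyl)-3-methylpyrrolidin-1-yl gives a 5.5-fold lower number from compound 2 to compound 3 (0.74 log units; beyond the scatter), so compound 3 is the stronger inhibitor of this pair. The earlier step concerned only the trifluoromethyl group, whereas this one holds that group fixed and shows that the amine-bearing ring at this position can also move the number beyond the scatter. The exchange replaces a five-membered ring with a six-membered ring and also removes the methyl and aminomethyl arrangement, but nothing given here bears on which of these differences accounts for the step.

Going by these compounds, whether 4-aminopiperidin-1-yl would give a step of similar size and direction with hydrogen in place of trifluoromethyl remains open. On these data alone, it is also open how a simpler 3-aminopyrrolidin-1-yl group or a piperazin-1-yl group would read at this position, which would help show whether ring size or the substitution on the ring goes with the change.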